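A few compounds are considered here, and "the series" means these few. Any claim that something is new, unique, unknown or untested is made for them only; others in the source may bear on it.

Working notes on the series, all in an assay on HEK293 cells for activation of Kir3.1/Kir3.2 (Homo sapiens), read by thallium flux; on this read-out lower numbers stand for an effect already at smaller amounts and higher numbers for an effect only at larger amounts of compound. Compound 1 `Cc1cc(NC(=O)Cn2nnc(-c3ccccc3)n2)n(C2CCC(F)(F)CC2)n1` gives 84 nM. Within the data shown here, compound 2 `CC1(c2cc(NC(=O)Cn3nnc(-c4ccccc4)n3)n(C3CCCCC3)n2)CC1` gives > 10000 nM, which is a limit of the assay and not a number; it is the one value that sits at the limit of > 10000 nM in this assay, at which 1 of the 3 values shown sits. Among the measured compounds shown here, compound 3 `Cc1cc(NC(=O)Cn2nnc(-c3cccc(Cl)c3)n2)n(C2CCCCC2)n1`, carrying 3-chlorophenyl, gives 300 nM in this assay, the higher of the two numbers measured so far, and its gap to compound 1 lies beyond the usual scatter.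

Compound 4 `Cc1cccc(-c2nnn(CC(=O)Nc3cc(C)nn3C3CCCCC3)n2)c1` has not yet been measured in this assay. It differs from compound 3 in one place: methyl in place of chloro on an aromatic carbon. For the measured compounds named here, no measured pair changes this position, so the size of the step has no direct precedent here. The step from compound 3 to compound 4 is expected to be small, with no direction beyond the scatter, estimated as no change at the digits printed from compound 3 to compound 4 (within the scatter). Compound 4 is therefore estimated at 300 nM, with a range from 120 nM to 800 nM.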

Compound 4, half-maximal effective concentration: 129 nM
Beside the measured number, compound 4's estimate is 2.3-fold (0.37 log units) above it, and the stated range covers the measured number.
By their numbers in this assay, from the lowest: compounds 1 and 4 (each within the scatter of the next); then compound 3. At a limit, above all of these: compound 2.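

In this assay, among these compounds, the only measured pair at this position on the aromatic ring shows that replacing chloro with methyl, with one heavy atom leaving and one entering and no change in hydrogen-bond donors, acceptors or net charge, gives a 2.3-fold lower number from compound 3 to compound 4 (0.37 log units; beyond the scatter). The step is modest, but it shows that the read-out responds to this exchange at this position, and compound 4 remains a measured value at 129 nM. Nothing shown gives a cause for the step.

Going by these compounds, how a hydrogen, a methoxy group, a nitrile or an amine at this carbon would compare with chloro and methyl remains open. Also open, on these data alone, is whether the same step holds on a different core, since it rests on this single pair.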